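Methoxy added to the fluorinated anilide of compound 2

The compounds below may be only part of what the source reports. "The series", "measured", "known", "first", "only" and "open" are said of these compounds alone.

Of the compounds shown here, two carry numbers so far. In a functional assay on A549 cells (Homo sapiens) for cytotoxicity, read by MTT assay, with a stated time of 72 h (a higher number here means a weaker inhibitor, a lower number a stronger inhibitor), compound 1 `COc1ccc(-c2cc(C(=O)Nc3ccc(Oc4ccnc5[nH]ccc45)cc3)ncn2)cc1` gives 4410 nM, and compound 2 `O=C(Nc1ccc(Oc2ccnc3[nH]ccc23)c(F)c1)c1cc(-c2ccccc2)ncn1` gives 180 nM; of the two, compound 2 stands at the lower number, and the gap to compound 1 lies beyond the scatter of repeated measurements. Going by the values given here, no pair differing in a single place has been measured, so the isolated effect of either group is unknown.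

Compound 3 `COc1ccc(-c2cc(C(=O)Nc3ccc(Oc4ccnc5[nH]ccc45)c(F)c3)ncn2)cc1` differs from compound 2 in one place: methoxy in place of hydrogen on an aromatic carbon. Among the compounds with values here, compound 1 already carries this methoxy group, without the fluorine, and sits at the higher of the two numbers, but no single step separates it from either compound.

The step from compound 2 to compound 3 is expected to be moderate and upward, a 5.0-fold higher number from compound 2 to compound 3 (0.70 log units; beyond the scatter), with wide uncertainty. In this assay compound 3 is estimated at 900 nM, within 250 nM to 4000 nM.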

Compound 3, half-maximal inhibitory concentration: 4210 nM
For compound 3 the middle estimate is 4.7-fold (0.67 log units) below the measured one, outside the stated range (above it).
By their numbers in this assay, from the lowest: compound 2; then compounds 3 and 1 (each within the scatter of the next).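

In this assay, the change from phenyl to 4-methoxyphenyl now has a measured size with the fluorine in place: a 23-fold higher number from compound 2 to compound 3 (1.37 log units; beyond the scatter), a large step. With the methoxy group present, fluoro in place of hydrogen on an aromatic carbon gives a 1.0-fold lower number from compound 1 to compound 3 (0.02 log units; within the scatter), so in this pair the fluorine leaves the number within the scatter. The data available give no explanation for the size of the methoxy step.

Going by these compounds, the fluoro step can be read only with the methoxy group present, so its size on the plain phenyl compound remains open. On these data alone, it also remains open whether the higher number is specific to methoxy or would also follow another group on the same carbon, such as a hydroxyl or an amine.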